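Swapping an anilino arm for piperazine on a shared core

The source may report more compounds than this note shows. Statements on the series, on what has been measured and on what is new or still open speak of the compounds shown alone.

Measured compounds:
compound 1, `N[C@H]1CC[C@H](Nc2c(C(=O)NCc3ccc(F)cc3)nc(N3CCCCC3)c3cccnc23)CC1`: "not determined" (no result reported)
compound 2, `Nc1ccc(Nc2c(C(=O)NCc3ccc(F)cc3)nc(Br)c3cccnc23)cc1`: 7000 nM
compound 3, `NCCCNc1c(C(=O)NCc2ccc(F)cc2)ncc2cccnc12`: > 10000 nM

Within the data shown here, in a functional assay on LNCaP cells (Homo sapiens) for cytotoxicity, read by MTT assay, with a stated time of 72 h (on this read-out lower numbers stand for stronger inhibition and higher numbers for weaker inhibition), compound 2 gives 7000 nM, the only plain number in the set. For compound 3 the read-out is a limit of the assay, > 10000 nM, so that the limit of > 10000 nM in this assay, at which 1 of the 3 values shown sits, is not a number. In this assay compound 1 gives "not determined" (no result reported). Compound 4, `O=C(NCc1ccc(F)cc1)c1nc(Br)c2cccnc2c1N1CCNCC1`, differs from compound 2 by piperazin-1-yl in place of (4-aminophenyl)amino on an aromatic carbon. No measured pair with a single change is available, so the size of this step cannot be read from the numbers shown. Compound 4 is expected to sit near compound 2, with a step of a 1.1-fold higher number from compound 2 to compound 4 (0.06 log units; within the scatter) that stays within the scatter. The estimate for compound 4 is 8000 nM, between 2500 nM and 25000 nM.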

Compound 4, half-maximal inhibitory concentration: 4500 nM
Compound 4: the middle estimate sits 1.8-fold (0.25 log units) above what was measured, and the stated range covers the measured number.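

In this assay, among these compounds, the change from (4-aminophenyl)amino to piperazin-1-yl on this aromatic carbon gives a 1.6-fold lower number from compound 2 to compound 4 (0.19 log units; within the scatter), the first single change that can be read at this position. In this one pair, the read-out does not separate an aromatic ring of carbon only from a non-aromatic ring with 2 hetero atoms at this place. Nothing shown gives a reason for this step.

As far as these compounds go, whether this holds without the bromo group on the shared core stays open. So does the outcome with morpholine or an open-chain amine such as dimethylamino at this position.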